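The source may hold more compounds than are shown below. What is called first, only, known or untested is meant among the compounds shown, and "the series" means these compounds.

Measured so far in an ADME assay on HUVEC cells (Homo sapiens) for antiproliferative activity, read by MTT assay, with a stated time of 48 h; on this read-out lower numbers stand for stronger inhibition and higher numbers for weaker inhibition:

In this assay compound 1 `N#CC1=C(N)Oc2c(c3nc4ccccc4nc3c3ccccc23)C12C(=O)N(Cc1cnnn1-c1ccc(Cl)cc1)c1ccccc12` gives > 50000 nM, which is a limit of the assay rather than a number.
In this assay compound 2 `N#CC1=C(N)Oc2c(c3nc4ccccc4nc3c3ccccc23)C12C(=O)N(Cc1cnnn1-c1ccccc1Cl)c1ccccc12` gives > 50000 nM, also a limit of the assay.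
In this assay compound 3 `N#CC1=C(N)Oc2c(N)cc3nc4ccccc4nc3c2C12C(=O)N(Cc1cnnn1-c1ccc(Cl)cc1)c1ccccc12` gives > 50000 nM, again a limit of the assay.

Compound 1 and compound 2 differ in one place only: 2-chlorophenyl in place of 4-chlorophenyl on an aromatic nitrogen. The resulting step that the two limits leave unreadable from compound 1 to compound 2 cannot be sized, since both ends are limits. Compound 3 has a different core from compound 1; how the two cores differ is not broken down here. Compound 4 `N#CC1=C(N)Oc2c(N)cc3nc4ccccc4nc3c2C12C(=O)N(Cc1cnnn1-c1ccccc1Cl)c1ccccc12` has not yet been measured; it stands to compound 3 as compound 2 stands to compound 1, carrying (2-chlorophenyl in place of 4-chlorophenyl on an aromatic nitrogen), the same change at the same place. Among the compounds with values here, because the limit of > 50000 nM in this assay, at which 3 of the 3 values shown sit, holds every measured value so far, the step from compound 3 to compound 4 is expected to stay unreadable, around a step that the limit leaves unreadable from compound 3 to compound 4. Compound 4 is therefore expected to land at 80000 nM, most likely reported as a limit, between 20000 nM and 300000 nM.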

Compound 4, half-maximal inhibitory concentration: > 50000 nM
Compound 4 gave a limit, no number; the forecaster's own chance of this, stated with the estimate: 85%; the middle value lies beyond the limit too.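

Compound 3 and compound 4 both sit at a limit of the assay rather than at a number, so no step can be read between them: the limit of > 50000 nM in this assay, at which 4 of the 4 values shown sit.

The compounds shown leave open whether 2-chlorophenyl and 4-chlorophenyl differ in strength at all, on either core.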